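Sulfonamido-benzoic acid series: biaryl replacements at the para position

The source may hold more compounds than are shown below. What is called first, only, known or untested is meant among the compounds shown, and "the series" means these compounds.

Compound 3 `CCCCCCCCS(=O)(=O)Nc1ccc(C(=O)c2ccc(OC)cc2)cc1C(=O)O` holds the second highest number among three: in an assay on mitochondria (strain BALB/c) for inhibition of glycerol-3-phosphate acyltransferase 1, mitochondrial (Mus musculus), read by scintillation counting, with a stated time of 10 min (on this read-out higher numbers stand for weaker inhibition and lower numbers for stronger inhibition), compound 3 gives 44300 nM, compound 2 `CCCCCCCCS(=O)(=O)Nc1ccc(-c2ccccc2O)cc1C(=O)O` gives 61700 nM, and compound 1 `CCCCCCCCS(=O)(=O)Nc1ccc(-c2ccccc2Cl)cc1C(=O)O` gives 14400 nM. Between them, a 3.1-fold higher number from compound 1 to compound 3 (0.49 log units; beyond the scatter) and a 1.4-fold lower number from compound 2 to compound 3 (0.14 log units; within the scatter); also a 4.3-fold higher number from compound 1 to compound 2 (0.63 log units; beyond the scatter). Compound 4 `CCCCCCCCS(=O)(=O)Nc1ccc(CCc2ccccc2)cc1C(=O)O` carries phenethyl in place of (4-methoxyphenyl)carbonyl on an aromatic carbon. Going by the values given here, no measured step covers a two-carbon link to the ring, so only the direction of a 3.1-fold higher number from compound 1 to compound 3 (0.49 log units; beyond the scatter) bears on it: a ring without the carbonyl sits at the lowest number so far. A modest lowering is therefore expected, as a 1.8-fold lower number from compound 3 to compound 4 (0.25 log units; within the scatter). Compound 4 is estimated at 25000 nM in this assay, within 7000 nM to 90000 nM.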

Compound 4, half-maximal inhibitory concentration: 37500 nM
Compound 4: middle estimate off by 1.5-fold (0.18 log units), on the low side, within the range that was stated.
By their numbers in this assay, from the lowest: compound 1; then compounds 4, 3 and 2 (each within the scatter of the next).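

In this assay, phenethyl at this position, a group without oxygen, stays level with the groups that carry it: a 1.2-fold lower number from compound 3 to compound 4 (0.07 log units; within the scatter), and a 1.6-fold lower number from compound 2 to compound 4 (0.22 log units; within the scatter). Only the 2-chlorophenyl group stands apart among the four, with a 2.6-fold higher number from compound 1 to compound 4 (0.42 log units; beyond the scatter), so losing the carbonyl alone does not reach the number of compound 1. Nothing available accounts for that separation.

Still open, as far as these compounds go, is whether a chloro on the phenethyl ring, or an amine or a longer chain in the link, would bring the number down to that of compound 1.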